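The source may report more compounds than this note shows. Statements on the series, on what has been measured and on what is new or still open speak of the compounds shown alone.

Measured so far in a functional assay on HeLa cells (Homo sapiens) for antiproliferative activity, with a stated time of 24 h; a higher number here means a weaker inhibitor, a lower number a stronger inhibitor:
compound 1 `NC(=O)c1c(NC(=O)c2ccccc2Cl)sc2c1CCN(Cc1ccccc1Cl)C2` — 27500 nM
compound 2 `NC(=O)c1c(NC(=O)c2ccccc2Cl)sc2c1CCN(Cc1c(Cl)cccc1Cl)C2` — 28800 nM
compound 3 `NC(=O)c1c(NC(=O)c2ccccc2Cl)sc2c1CCN(Cc1cc(Cl)cc(Cl)c1)C2` — 19600 nM

All three share one core and differ only in the group on the amine nitrogen in the ring. The steps between them are small: a 1.0-fold higher number from compound 1 to compound 2 (0.02 log units; within the scatter); a 1.4-fold lower number from compound 1 to compound 3 (0.15 log units; within the scatter); a 1.5-fold lower number from compound 2 to compound 3 (0.17 log units; within the scatter). Compound 3 has the lowest number of the three, but its steps to compound 1 and to compound 2 both lie within the scatter, so no order among the three compounds can be claimed.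

Compound 4 `NC(=O)c1c(NC(=O)c2ccccc2Cl)sc2c1CCN(C(=O)Nc1ccccc1Cl)C2` is not yet measured. Relative to compound 3 the change is (2-chlorophenyl)carbamoyl in place of 3,5-dichlorobenzyl on an amine nitrogen in a ring. For the measured compounds named here, no measured step bears on this change directly. The three measured steps swap one chlorinated benzyl for another, whereas here the benzyl is replaced by a carbamoyl group. Going by the values given here, what the series does show is that the three benzyl variants stayed within the scatter of one another, and that is the only guide available. For compound 4 the expectation is therefore a number near that of compound 3, estimated at 25000 nM with a range of 8000 nM to 80000 nM. The expected step of a 1.3-fold higher number from compound 3 to compound 4 (0.11 log units; within the scatter) is not beyond the scatter. The range is kept wide, as the change is of a different kind from the measured ones.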

Compound 4, half-maximal inhibitory concentration: 45400 nM
Beside the measured number, compound 4's estimate is 1.8-fold (0.26 log units) below it; the range from low to high includes it.
By their numbers in this assay, from the lowest: compounds 3, 1, 2 and 4 (each within the scatter of the next, the first and the last beyond it).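

Placing (2-chlorophenyl)carbamoyl on the amine nitrogen in the ring gives the first step at this position to lie beyond the scatter in this assay, modest in size: a 2.3-fold higher number from compound 3 to compound 4 (0.36 log units; beyond the scatter). The same replacement read against the other two benzyl groups stays within the scatter, at a 1.6-fold higher number from compound 2 to compound 4 (0.20 log units; within the scatter) and a 1.7-fold higher number from compound 1 to compound 4 (0.22 log units; within the scatter), so the carbamoyl group separates from 3,5-dichlorobenzyl only, and the series gives no general difference between carbamoyl and chlorinated benzyl groups at this position. No evidence at hand accounts for the step from 3,5-dichlorobenzyl to (2-chlorophenyl)carbamoyl.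

The compounds shown leave open whether the separation belongs to the carbamoyl link or to the chlorine pattern on the aromatic ring, a question that a (3,5-dichlorophenyl)carbamoyl group on the same nitrogen would address directly alongside compound 3. Also open, from the compounds shown here alone, is how the position reads without any aromatic ring, as with an acetyl or a methyl group on that nitrogen, or with a plain unsubstituted benzyl group as the reference for all the chlorinated ones.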